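From chloro to tert-butyl: an expected growth inhibition

The source may report more compounds than this note shows. Statements on the series, on what has been measured and on what is new or still open speak of the compounds shown alone.

In a functional assay on A549 cells (Homo sapiens) for inhibition, read by CCK-8 assay, with a stated time of 72 h, tested at 8 uM (a higher number here means more inhibition of growth at the concentration tested, a lower number less inhibition of growth), compound 1 (`Nc1ccccc1NC(=O)/C=C/c1ccc(CSc2ccc(Cl)cc2)cc1`) gives 59.6% and stands lowest of the three measured compounds. Compound 2 (`COc1ccc(SCc2ccc(C(=O)Nc3ccccc3N)cc2)cc1`) reaches 70.7% and lies beyond the scatter from compound 1. Compound 3 (`Nc1ccccc1NC(=O)c1ccc(CSc2nccc(C(F)(F)F)n2)cc1`) reaches 95.1% and lies further still from compound 1, also beyond the scatter.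

The next compound to be tested is compound 4 (`CC(C)(C)c1ccc(SCc2ccc(/C=C/C(=O)Nc3ccccc3N)cc2)cc1`). Its change from compound 1 is tert-butyl in place of chloro on an aromatic carbon and amounts to tert-butyl in place of chloro on an aromatic carbon, para to a large group. Among the measured compounds shown here, no measured pair of compounds differs in only one place, so the data give no direct guide to the size or direction of this change. A step of a number 4.6 percentage points lower from compound 1 to compound 4 (within the scatter) is therefore expected, a small decrease that would stay within the scatter, with wide uncertainty on either side. In this assay compound 4 is estimated at 55% (expected range 33% to 77%).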

Compound 4, percent growth inhibition at one concentration: 79.8%
Compound 4: the middle estimate sits 24.8 percentage points below what was measured, outside the stated range (above it).
By their numbers in this assay, from the lowest: compound 1; then compounds 2 and 4 (each within the scatter of the next); then compound 3.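

In this assay, among the compounds shown here, tert-butyl in place of chloro on this aromatic carbon, para to a large group, gives the first comparison that differs in one place only, and it reads a number 20.2 percentage points higher from compound 1 to compound 4 (beyond the scatter) on the core of compound 1. For the compounds shown here, this position therefore takes tert-butyl with a gain in growth inhibition rather than a loss, which the earlier compounds, differing from one another in more than one place, could not show. That conclusion rests on this single pair, and nothing shown bears on what lies behind the rise.

From the compounds shown here alone, it remains open whether a methyl group, an amine or a carboxylic acid at the same position would move the number up or down. Also open, going by these compounds, is whether the change from 4-chlorophenyl to 4-(tert-butyl)phenyl would give a similar step on another core.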